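The source may hold more compounds than are shown below. What is called first, only, known or untested is meant among the compounds shown, and "the series" means these compounds.

Working notes on the series

The shared core of compound 1 `FC(F)(F)c1ccc(CSc2nc(Nc3ccccc3)c3ccccc3n2)cc1` carries a phenyl on the ring nitrogen; in a functional assay on HGC-27 cells (Homo sapiens) for cytotoxicity, read by MTT assay, with a stated time of 72 h (on this read-out lower numbers stand for stronger inhibition and higher numbers for weaker inhibition), compound 1 gives 26400 nM, which is the second highest of the three numbers measured, with compound 2 nearest and compound 3 furthest, both within the scatter. Compound 2 `Cc1ccc(Nc2nc(SCc3ccc(C(F)(F)F)cc3)nc3ccccc23)cc1` gives 34600 nM and compound 3 `COc1ccc(Nc2nc(SCc3ccc(C(F)(F)F)cc3)nc3ccccc23)cc1OC` gives 17900 nM. The step of a 1.3-fold higher number from compound 1 to compound 2 (0.12 log units; within the scatter) and the step of a 1.5-fold lower number from compound 1 to compound 3 (0.17 log units; within the scatter) both stay within the scatter, as does a 1.9-fold lower number from compound 2 to compound 3 (0.29 log units; within the scatter).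

Compound 4 `Fc1ccc(Nc2nc(SCc3ccc(C(F)(F)F)cc3)nc3ccccc23)cc1Cl` differs from compound 1 by 3-chloro-4-fluorophenyl in place of phenyl on a nitrogen on an aromatic ring. Among the measured compounds shown here, the steps that bear on this are the two that also exchange the group on the ring nitrogen, a 1.5-fold lower number from compound 1 to compound 3 (0.17 log units; within the scatter) and a 1.9-fold lower number from compound 2 to compound 3 (0.29 log units; within the scatter); neither moved the number beyond the scatter. For the measured compounds named here, no measured step introduces a halogen on that ring, so the expectation rests on the flat behaviour seen so far. For compound 4 the number in this assay is expected to stay close to compound 1, a step of a 1.3-fold lower number from compound 1 to compound 4 (0.10 log units; within the scatter), with no direction claimed beyond the scatter. Compound 4 is therefore estimated at 21000 nM, with a range from 8000 nM to 55000 nM.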

Compound 4, half-maximal inhibitory concentration: 14700 nM
For compound 4 the middle estimate is 1.4-fold (0.15 log units) above the measured one; the range from low to high includes it.
By their numbers in this assay, from the lowest: compounds 4, 3, 1 and 2 (each within the scatter of the next, the first and the last beyond it).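

In this assay, among the compounds shown here, 3-chloro-4-fluorophenyl on a nitrogen on an aromatic ring gives the first step at this position that lies beyond the scatter (a 2.4-fold lower number from compound 2 to compound 4 (0.37 log units; beyond the scatter)), and that step is modest. Against the other two groups the same exchange stays within the scatter (a 1.8-fold lower number from compound 1 to compound 4 (0.25 log units; within the scatter); a 1.2-fold lower number from compound 3 to compound 4 (0.09 log units; within the scatter)), so the separation holds only against 4-methylphenyl, and compound 1 and compound 3 go against any general gain from the halogenated ring. The data shown include no evidence that bears on the origin of this step.

Chlorine and fluorine enter together in compound 4, so the contribution of each halogen alone stays open. All four compounds keep a six-membered aromatic ring of carbon only at this place, which leaves open what a morpholine, a carboxylic acid or a longer chain would do there.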